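The source may hold more compounds than are shown below. What is called first, only, known or untested is meant among the compounds shown, and "the series" means these compounds.

Among the measured compounds shown here, in a functional assay on the whole organism (strain Wistar) with Rattus norvegicus as the target, read by paw edema, at a dose of 30 mg/kg by the oral route (on this read-out higher numbers stand for an effect only at larger amounts of compound and lower numbers for an effect already at smaller amounts), compound 2 `CCC(=O)OCc1cc(-n2nc(C(F)(F)F)cc2-c2ccc3c(c2)CCC3)ccc1S(N)(=O)=O` gives 30 mg/kg, the only number for it, with one further entry that has no single number. Compound 3 `CCC(=O)NS(=O)(=O)c1ccc(-n2nc(C(F)(F)F)cc2-c2ccc3c(c2)CCC3)cc1COC(=O)CC` differs from compound 2 by propanoyl in place of hydrogen on a sulfonamide nitrogen. Compound 1 `CCC(=O)NS(=O)(=O)c1ccc(-n2nc(C(F)(F)F)cc2-c2ccc3c(c2)CCO3)cc1COC(=O)CC` already carries propanoyl on a sulfonamide nitrogen, on a different core, and gives 25 mg/kg; 43 mg/kg (2 entries), which lies within the scatter of the number for compound 2. No step beyond the scatter is therefore expected in this assay, in either direction. The expected change is no change at the digits printed from compound 2 to compound 3 (within the scatter). For compound 3 the estimated value is 30 mg/kg, with an expected range of 14 mg/kg to 60 mg/kg.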

Compound 3, dose for half-maximal effect: 41 mg/kg
Compound 3: middle estimate off by 1.4-fold (0.14 log units), on the low side; the measured number falls inside the stated range.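

Propanoyl in place of hydrogen on a sulfonamide nitrogen can now be read on a single core: in this assay the change gives a 1.4-fold higher number from compound 2 to compound 3 (0.14 log units; within the scatter). Before this, the group could only be seen on a different core, so this is the first direct reading of the change at this position. The step is no wider than the spread between repeat entries of one compound: the several entries of compound 1 in this assay, 25 mg/kg; 43 mg/kg (2 entries)

On these data alone, it remains open whether the same change reads alike on the core of compound 1. Also open, as far as these compounds go, is whether a longer chain such as hexanoyl, or a benzoyl group, on a sulfonamide nitrogen moves the number beyond the scatter.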